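The compounds below may be only part of what the source reports. "The series", "measured", "known", "first", "only" and "open" are said of these compounds alone.

Three sulfonyl variants on one shared core have so far been run in an ADME assay on microsomes from liver (Rattus norvegicus) for metabolic stability, with a stated time of 10 min; on this read-out lower numbers stand for a less stable compound and higher numbers for a more stable compound. Compound 1 `CC(C)S(=O)(=O)NC(=O)c1ccc(Nc2nc(NC3(c4ccc(Cl)cc4)CC3)nc(OCC(F)(F)F)n2)cc1` gives 96% in this assay. Compound 2 `O=C(NS(=O)(=O)c1ccccc1)c1ccc(Nc2nc(NC3(c4ccc(Cl)cc4)CC3)nc(OCC(F)(F)F)n2)cc1` gives 100% in this assay. Compound 3 `CC(=O)NCCS(=O)(=O)NC(=O)c1ccc(Nc2nc(NC3(c4ccc(Cl)cc4)CC3)nc(OCC(F)(F)F)n2)cc1` gives 100% in this assay. All three pairwise steps fall inside the scatter: a number 4 percentage points higher from compound 1 to compound 2 (within the scatter), a number 4 percentage points higher from compound 1 to compound 3 (within the scatter) and no change at the digits printed from compound 2 to compound 3 (within the scatter). On the reported figures compound 3 stands level with compound 2 and within the scatter of compound 1, so the three measured sulfonyl groups cannot be told apart in this assay.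

Compound 4 `Cc1ccccc1S(=O)(=O)NC(=O)c1ccc(Nc2nc(NC3(c4ccc(Cl)cc4)CC3)nc(OCC(F)(F)F)n2)cc1` is the next sulfonyl variant; relative to compound 3 the change is 2-methylphenyl in place of 2-acetamidoethyl on a sulfonyl sulfur. The step that bears most directly on it is no change at the digits printed from compound 2 to compound 3 (within the scatter), which swapped an aromatic sulfonyl group for the same 2-acetamidoethyl group and moved nothing beyond the scatter; a number 4 percentage points higher from compound 1 to compound 3 (within the scatter), between an alkyl group and the 2-acetamidoethyl group, was equally flat. With every recorded sulfonyl exchange lying inside the scatter, no step beyond the scatter is expected in this assay for compound 4, and the expected step of a number 2 percentage points lower from compound 3 to compound 4 (within the scatter) is taken as flat. Compound 4 is accordingly estimated at 98%, with a range of 86% to 100%.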

Compound 4, percent of the compound remaining: 100%
The estimate for compound 4 lay 2 percentage points below the measured number; the measured number falls inside the stated range.
By their numbers in this assay, from the lowest: compounds 1, 2, 3 and 4 (each within the scatter of the next).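

In this assay, 2-methylphenyl in place of 2-acetamidoethyl on the sulfonyl sulfur gives no change at the digits printed from compound 3 to compound 4 (within the scatter) even though the entering group has a six-membered aromatic ring of carbon only and 0 hydrogen-bond donors or acceptors, while the leaving group has no ring and 1 of each. Methyl in place of hydrogen on an aromatic carbon, a smaller change to the aromatic sulfonyl group, gives no change at the digits printed from compound 2 to compound 4 (within the scatter) and the exchange of isopropyl for 2-methylphenyl gives a number 4 percentage points higher from compound 1 to compound 4 (within the scatter) so this read-out separates neither the added methyl nor any of the four sulfonyl groups shown. No supporting measurement is available to explain this flat behaviour.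

Going by these compounds, whether a 2-aminoethyl chain, a carboxylic acid on the chain or a longer alkyl chain on this sulfonyl sulfur would give a step beyond the scatter remains open. On these data alone, all four compounds share the rest of the structure, so the effect on this read-out of any change elsewhere on the shared core also remains open.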